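Two fluorines in place of two chlorines

This account rests on a few compounds, and the source may have more. Where it says the series, first, only, none or still open, it means among the compounds named here.

Compound 1 `COc1cc(-c2cc(/C=C/C(=O)c3ccc(Cl)c(Cl)c3)[nH]n2)cc(OC)c1OC`: 390 nM
Compound 2 `COc1ccc(-c2cc(/C=C/C(=O)c3ccc(N)cc3)[nH]n2)cc1`: 790 nM
Compound 3 `COc1cc(C(=O)/C=C/c2cc(-c3cc(OC)c(OC)c(OC)c3)n[nH]2)cc(OC)c1OC`: 390 nM

In a functional assay on SR cells (Homo sapiens) for inhibition, read by sulforhodamine B assay, with a stated time of 48 h (on this read-out higher numbers stand for weaker inhibition of growth and lower numbers for stronger inhibition of growth), compound 1 gives 390 nM, level with compound 3 at the digits shown, and together these two are the lowest of the three numbers. Compound 2 stands furthest off with 790 nM, a gap beyond the scatter. Compound 4 `COc1cc(-c2cc(/C=C/C(=O)c3ccc(F)c(F)c3)[nH]n2)cc(OC)c1OC` differs from compound 1 in a single place: 3,4-difluorophenyl in place of 3,4-dichlorophenyl on a carbonyl carbon. Within the data shown here, no measured pair shows what such a halogen swap does here, so the expectation rests on compound 1 alone. A modest step is expected from compound 1 to compound 4, a 1.5-fold higher number from compound 1 to compound 4 (0.19 log units; within the scatter), toward a somewhat higher number, near the edge of the scatter. Compound 4 is thus estimated at 600 nM, within 250 nM to 1500 nM.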

Compound 4, concentration for 50% growth inhibition: 2920 nM
The estimate for compound 4 lay 4.9-fold (0.69 log units) below the measured number; the whole stated range lies below it.
By their numbers in this assay, from the lowest: compounds 1 and 3 (each within the scatter of the next); then compound 2; then compound 4.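

At this place, on a carbonyl carbon, the identity of the halogen clearly matters: 3,4-difluorophenyl in place of 3,4-dichlorophenyl gives a 7.5-fold higher number from compound 1 to compound 4 (0.87 log units; beyond the scatter) even though both groups have the same count of heavy atoms and the same ring. In this one pair, growth inhibition is weaker with fluorine than with chlorine. Nothing measured here explains the gap.

Still open, on these data alone, is how other groups would fare at this place, such as 3,4-dibromophenyl or 3,4-dimethylphenyl. These would show whether the trend follows halogen size or something else.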